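The source may hold more compounds than are shown below. What is called first, only, known or untested is meant among the compounds shown, and "the series" means these compounds.

Working notes on the series. Compound 1 `CC(=O)NCc1ccccc1-c1ccc(COC2CC[C@H](N3CCCCCC3)[C@H]2OC/C=C\CCC(=O)O)cc1` gives 126 nM in a functional assay for antagonist activity at thromboxane A2 receptor (Rattus norvegicus) (on this read-out higher numbers stand for weaker binding and lower numbers for tighter binding), the highest of the two single numbers in hand. Compound 2 `O=C(O)CC/C=C\CO[C@H]1[C@@H](OCc2ccc(-c3ccccc3CO)cc2)CC[C@@H]1N1CCCCCC1` gives 12.6 nM in this assay, a lower number beyond the scatter. Compound 3 `O=C(O)CC/C=C\CO[C@H]1C(OCc2ccc(-c3ccccc3)cc2)CC[C@@H]1N1CCCCC1` has two entries in this assay, 794 nM; 63.1 nM (2 entries), and the several entries of compound 3 in this assay, 794 nM; 63.1 nM (2 entries) shows how far repeats of one compound can sit apart here.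

Compound 4 `O=C(O)CC/C=C\CO[C@H]1C(OCc2ccc(-c3ccccc3CO)cc2)CC[C@@H]1N1CCCCCC1` is not yet measured in this assay. It differs from compound 1 in one place: hydroxy in place of acetamido on a saturated chain carbon bound to an aromatic carbon. Within the data shown here, no measured step covers this change. Compound 2 carries the same hydroxymethyl group and gives the lowest number seen, so a lower number is expected for compound 4. Compound 4 is expected at 25 nM, with a range of 8 nM to 80 nM, an estimated step of a 5.0-fold lower number from compound 1 to compound 4 (0.70 log units; beyond the scatter).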

Compound 4, dissociation constant: 6.31 nM
Estimate against measurement, compound 4: 4.0-fold (0.60 log units) above, outside the stated range (below it).
By their numbers in this assay, from the lowest: compounds 4 and 2 (each within the scatter of the next); then compound 1.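

Hydroxy in place of acetamido on a saturated chain carbon bound to an aromatic carbon gives, in this assay, a 20-fold lower number from compound 1 to compound 4 (1.30 log units; beyond the scatter), the only measured step at this position. The stereocentre at a saturated ring carbon, drawn S on one side and without a configuration on the other, gives a 2.0-fold lower number from compound 2 to compound 4 (0.30 log units; within the scatter), so no effect of that configuration can be read.

From the compounds shown here alone, whether an amine, a carboxylic acid or a longer chain bearing the hydroxy would match hydroxy at this carbon stays open. Repeats also limit how finely small steps can be read: the several entries of compound 3 in this assay, 794 nM; 63.1 nM (2 entries)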